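A 4-chlorobenzyl group carried from one core to another

The source may hold more compounds than are shown below. What is called first, only, known or untested is meant among the compounds shown, and "the series" means these compounds.

The study gathers four compounds built from the same parts. Compound 3 `COc1ccc2[nH]cc(C3CC(c4ccncc4)=NO3)c2c1` carries a hydrogen on an aromatic nitrogen, and compound 1 `COc1ccc2c(c1)c(C1CC(c3ccncc3)=NO1)cn2Cc1ccc(Cl)cc1` is its counterpart with a 4-chlorobenzyl group there. Compound 2 `COc1ccc2c(C3CC(c4ccncc4)=NO3)c[nH]c2c1` has the same atoms as compound 3, joined differently; the difference between the two cores is not broken down here. Compound 4 `COc1ccc2c(C3CC(c4ccncc4)=NO3)cn(Cc3ccc(Cl)cc3)c2c1` is compound 2 bearing the same 4-chlorobenzyl group.

In a functional assay on HEK293 cells (Homo sapiens) for inhibition, read by MTT assay, with a stated time of 48 h (on this read-out higher numbers stand for weaker inhibition and lower numbers for stronger inhibition), compound 3 reaches only the limit of > 100000 nM, and this is a limit rather than a number. Compound 1 gives 14200 nM in this assay. The change between them, (4-chlorobenzyl in place of hydrogen on an aromatic nitrogen), produced the step of an at least 7.0-fold lower number from compound 3 to compound 1 (0.84 log units; beyond the scatter), whose size is known only as a minimum because of the limit of > 100000 nM in this assay, at which 1 of the 3 values shown sits. Compound 2 gives 4160 nM in this assay, the lower of the two numbers measured; compound 1 sits a gap beyond the scatter above it.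

The change from compound 2 to compound 4 is 4-chlorobenzyl in place of hydrogen on an aromatic nitrogen. The place is described in the same words for both pairs, so it is the same change. Its step is expected to be a 4.6-fold lower number from compound 2 to compound 4 (0.66 log units; beyond the scatter), resting on the step of an at least 7.0-fold lower number from compound 3 to compound 1 (0.84 log units; beyond the scatter) seen for compound 3 and compound 1. Compound 4 is therefore estimated to give about 900 nM in this assay, expected to fall between 250 nM and 4000 nM.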

Compound 4, half-maximal inhibitory concentration: 37200 nM
For compound 4 the middle estimate is 41-fold (1.62 log units) below the measured one, outside the stated range (above it).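

In this assay, 4-chlorobenzyl in place of hydrogen on an aromatic nitrogen gave an 8.9-fold higher number from compound 2 to compound 4 (0.95 log units; beyond the scatter), which means weaker inhibition on this core, whereas the same change went with stronger inhibition on the other core, so it did not carry from one core to the other: the same change on two cores in this assay, an at least 7.0-fold lower number (0.84 log units; beyond the scatter) from compound 3 to compound 1 and an 8.9-fold higher number (0.95 log units; beyond the scatter) from compound 2 to compound 4, at least 62-fold (1.79 log units) apart, beyond the scatter of two such steps. Compound 3 stands at a limit and not at a number, so the earlier step is known only as a minimum, yet its direction is still the opposite one: the limit of > 100000 nM in this assay, at which 1 of the 4 values shown sits. What this shows is that in these two pairs the outcome of the change depends on the core it is placed on, while it does not show why the two cores differ, and two pairs give no rule for the rest of the series.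

The compounds shown leave open whether another group on the same nitrogen, such as a methyl, an unsubstituted benzyl or a longer chain ending in an amine, would split between the two cores in the same way. They also leave open whether the split belongs to the 4-chlorobenzyl group alone or would appear with any group placed there.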